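A few compounds are considered here, and "the series" means these few. Any claim that something is new, unique, unknown or untested is made for them only; others in the source may bear on it.

Measured compounds:
compound 1, `CNc1nc(NCCCN(C)C)c2sc(-c3ccc(N)cc3)cc2n1`, > 100 ug/mL
compound 2, `CNc1nc(NCCCN(C)C)c2sc(-c3ccc(OC)nc3)cc2n1`, > 100 ug/mL
compound 3, `CNc1nc(NCCCN(C)C)c2sc(-c3ccc(C(C)=O)cc3)cc2n1`, > 100 ug/mL

The three compounds share one core and differ only in the aryl group on the aromatic carbon next to the ring sulfur. In a physicochemical assay for solubility, at pH 2 (a lower number here means a less soluble compound, a higher number a more soluble compound), compound 1 reports a limit, > 100 ug/mL. Compound 2 likewise reports a limit, > 100 ug/mL. Compound 3 also stands at a limit, > 100 ug/mL. Within the data shown here, because of the limit of > 100 ug/mL in this assay, at which 3 of the 3 values shown sit, the steps a step that the two limits leave unreadable from compound 1 to compound 2, a step that the two limits leave unreadable from compound 1 to compound 3 and a step that the two limits leave unreadable from compound 2 to compound 3 cannot be read for size or direction; they show only that every aryl group tried so far leaves the compound at the limit.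

Compound 4, `CNc1nc(NCCCN(C)C)c2sc(-c3ccoc3)cc2n1`, is not yet measured. It differs from compound 3 as follows: furan-3-yl in place of 4-acetylphenyl on an aromatic carbon. Among the measured compounds shown here, no measured step gives a readable size to lean on, and the value of compound 3 is itself a limit. Compound 4 is therefore expected to stand at 150 ug/mL, with a range from 60 ug/mL to 400 ug/mL. The expected step is a step that the limit leaves unreadable from compound 3 to compound 4, most likely again reported as a limit.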

Compound 4, solubility: 221 ug/mL
The estimate for compound 4 lay 1.5-fold (0.17 log units) below the measured number; low and high end bracket the measured number.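

The steps to compound 4 from compound 1, compound 2 and compound 3 cannot be read for size or direction, because those three compounds each stand at a limit: the limit of > 100 ug/mL in this assay, at which 3 of the 4 values shown sit. In this assay the compounds shown leave open whether compound 1, compound 2 or compound 3 differs from compound 4 at all.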